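A few compounds are considered here, and "the series" means these few. Any claim that something is new, unique, unknown or untested is made for them only; others in the source may bear on it.

Measured compounds:
- compound 1, `FC(F)(F)c1cc(NC[C@H]2CCCN2)c2cn[nH]c2c1`: in an assay for inhibition of Indoleamine 2,3-dioxygenase 1 (Homo sapiens), with stated times of 10 min and 60 min (a lower number here means a stronger inhibitor, a higher number a weaker inhibitor), compound 1 gives 9580 nM
- compound 2, `COc1cc(CNc2cc(Br)cc3[nH]ncc23)c([N+](=O)[O-])cc1OC`: in this assay compound 2 gives 18500 nM

Going by the values given here, of the two numbers that have been measured, compound 1 has the lower one, but the gap to compound 2 lies within the usual scatter of repeated measurements, so the two cannot be ranked against each other and no step between them is counted. Both sit far from the potent end of the scale, and they share only the core that is drawn in their structures, with different groups around it.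

Compound 3, `FC(F)(F)c1cc(NC[C@H]2CCCCN2)c2cn[nH]c2c1`, has not yet been measured. It differs from compound 1 in one place: piperidin-2-yl in place of pyrrolidin-2-yl on a saturated chain carbon bound to a nitrogen on an aromatic ring. The ring that carries the amine is made one carbon larger, while the donor and acceptor count and the stereocentre stay as they were. Among the compounds with values here, no pair of measured compounds shows what such a ring enlargement does on this core, so the expectation rests on the structural change alone. A shift of this kind is expected to move the number little, and the estimated step from compound 1 to compound 3 is a 1.2-fold lower number from compound 1 to compound 3 (0.08 log units; within the scatter). Compound 3 is therefore expected to give about 8000 nM in this assay, in the range from 2500 nM to 25000 nM.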

Compound 3, half-maximal inhibitory concentration: 24000 nM
For compound 3 the middle estimate is 3.0-fold (0.48 log units) below the measured one; the range from low to high includes it.
By their numbers in this assay, from the lowest: compounds 1, 2 and 3 (each within the scatter of the next, the first and the last beyond it).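

In this assay, piperidin-2-yl in place of pyrrolidin-2-yl on a saturated chain carbon bound to a nitrogen on an aromatic ring gives a 2.5-fold higher number from compound 1 to compound 3 (0.40 log units; beyond the scatter), the first difference in this small set that lies beyond the scatter and can be tied to a single change. The position therefore responds to the size of this ring: one more ring carbon, with the donor and acceptor counts, the neutral charge and the single defined stereocentre all unchanged, is enough to give a weaker inhibitor, although the step is modest. The compounds show the size and direction of this step but offer no measurement that could explain it.

From the compounds shown here alone, it remains open whether a smaller azetidin-2-yl ring or an open-chain group such as 2-aminoethyl would give a lower or a higher number at this position, and what the opposite configuration at the stereocentre would do. Going by these compounds, compound 2 differs from compound 1 in more than one place, so it remains unknown whether the same ring change would have a similar effect with the bromine-bearing core or the groups of compound 2.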